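The source may report more compounds than this note shows. Statements on the series, on what has been measured and on what is new or still open speak of the compounds shown alone.

Measured so far in a functional assay for activation of Alpha-1A adrenergic receptor (Homo sapiens), read by calcium flux; on this read-out higher numbers stand for an effect only at larger amounts of compound and lower numbers for an effect already at smaller amounts:
Compound 1 `Cc1nc(-c2ccccc2NCC2=NCCN2)cs1` gives 4.47 nM.
Compound 2 `c1ccc(-c2cnoc2)c(NCC2=NCCN2)c1` gives 45.7 nM.
Compound 3 `Cc1noc(-c2ccccc2NCC2=NCCN2)n1` gives 661 nM.

Compound 3 stands at the highest number of the three: the step of a 150-fold higher number from compound 1 to compound 3 (2.17 log units; beyond the scatter) and the step of a 14-fold higher number from compound 2 to compound 3 (1.16 log units; beyond the scatter) both lie beyond the scatter, so compound 3 is the least potent of the measured set.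

Compound 4 `CO/N=C(\C)c1ccccc1NCC1=NCCN1` differs from compound 3 in one place: a group of 5 heavy atoms (3 carbon, 1 nitrogen, 1 oxygen; no ring) in place of a group of 6 heavy atoms (3 carbon, 2 nitrogen, 1 oxygen; one five-membered aromatic ring with 3 hetero atoms), on an aromatic carbon. Among the compounds with values here, no measured step exchanges a ring for an open chain at this position, so none bears on the change directly. What the three measured steps do show is that the group at this position governs the read-out strongly: a 10-fold higher number from compound 1 to compound 2 (1.01 log units; beyond the scatter), a 14-fold higher number from compound 2 to compound 3 (1.16 log units; beyond the scatter) and a 150-fold higher number from compound 1 to compound 3 (2.17 log units; beyond the scatter) were all large. A step beyond the scatter is therefore expected in this assay, and since compound 3 is the highest number of the set, the lean is toward a lower number, though with wide uncertainty. For compound 4 the expected value is 150 nM, in the range 30 nM to 800 nM, an estimated step of a 4.4-fold lower number from compound 3 to compound 4 (0.64 log units; beyond the scatter).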

Compound 4, half-maximal effective concentration: 20.9 nM
Compound 4: middle estimate off by 7.2-fold (0.86 log units), on the high side; measured number below the stated range.
By their numbers in this assay, from the lowest: compound 1; then compound 4; then compound 2; then compound 3.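

In this assay, the open chain of compound 4 shows that this place on the aromatic carbon does not need a five-membered aromatic ring: a 32-fold lower number from compound 3 to compound 4 (1.50 log units; beyond the scatter) takes the number well down from that of the 3-methyl-1,2,4-oxadiazol-5-yl group, and a 2.2-fold lower number from compound 2 to compound 4 (0.34 log units; beyond the scatter) puts the chain ahead of the 1,2-oxazol-4-yl ring. The 2-methyl-1,3-thiazol-4-yl group still holds the lowest number, with a 4.7-fold higher number from compound 1 to compound 4 (0.67 log units; beyond the scatter) as the step, so the chain sits among the rings and the presence of a ring alone does not set the order. Nothing available here accounts for this order of the four groups.

The compounds shown leave open how an open chain built around an amide would read at this place. They also leave open whether a 1,3-thiazol-4-yl ring without its methyl group would keep the number of compound 1.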